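The source may hold more compounds than are shown below. What is called first, only, known or untested is meant among the compounds shown, and "the series" means these compounds.

In a functional assay on A549 cells (Homo sapiens) for inhibition, read by sulforhodamine B assay, tested at 10 uM (a higher number here means more inhibition of growth at the concentration tested, a lower number less inhibition of growth), compound 1, with the structure `COc1ccc(C2CC(c3ccc(OCc4cn(Cc5ccc([N+](=O)[O-])cc5)nn4)cc3)=NN2C(C)=O)cc1`, gives 26%. Compound 2, with the structure `COc1cc(C2CC(c3ccccc3)=NN2C(C)=O)ccc1OCc1cn(Cc2ccc([N+](=O)[O-])cc2)nn1`, gives 0% in this assay. Of the two numbers in hand, compound 2 stands lowest; its nearest neighbour is compound 1, whose number lies higher by a gap beyond the usual scatter of this kind of measurement. The two compounds differ in more than one place, so no single structural step can be read from that gap.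

Compound 3, with the structure `COc1cc(C2CC(c3cccc4ccccc34)=NN2C(C)=O)ccc1OCc1cn(Cc2ccc([N+](=O)[O-])cc2)nn1`, has not yet been measured. It differs from compound 2 in one place: naphthalen-1-yl in place of phenyl on a carbon with a double bond to nitrogen. Within the data shown here, no pair of measured compounds shows a step of this kind, so the expectation for compound 3 in this assay rests on the low number of compound 2 alone. A small step upward is expected, a number 15 percentage points higher from compound 2 to compound 3 (beyond the scatter), of a size that need not exceed the scatter. Compound 3 is thus expected to give about 15% in this assay, within a range from 0% to 40%.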

Compound 3, percent growth inhibition at one concentration: 89%
Compound 3: middle estimate off by 74 percentage points, on the low side; the measured number lies above the stated range.
By their numbers in this assay, from the lowest: compound 2; then compound 1; then compound 3.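

In this assay, naphthalen-1-yl in place of phenyl on the carbon with a double bond to nitrogen gives a number 89 percentage points higher from compound 2 to compound 3 (beyond the scatter), a large step and the first that can be read from a change in one place, showing that the outcome in this series is highly sensitive to the group at this position. The change adds a second six-membered aromatic ring of carbon only, while neither group carries a hydrogen-bond donor, a hydrogen-bond acceptor or a net charge, so the two compounds differ here only in the carbon aromatic group at this one position. No measurement shown accounts for the size of this step, and the reason for it remains unknown.

The compounds shown leave open whether the step depends on the second ring itself or on how it is attached, a question that naphthalen-2-yl, quinolin-8-yl or a benzyl group at the same position would bear on. They also leave open whether naphthalen-1-yl would give a step of similar size on the core of compound 1, where the triazole-bearing ether chain sits elsewhere.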